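The source may hold more compounds than are shown below. What is called first, only, known or untested is meant among the compounds shown, and "the series" means these compounds.

Compound 1, `NCC[C@@H]1CCOC(c2ccccc2)(c2ccccc2)O1`: in an assay for displacement of a labelled ligand from Sigma non-opioid intracellular receptor 1 (Cavia porcellus), read by scintillation counting (on this read-out higher numbers stand for weaker inhibition and lower numbers for stronger inhibition), compound 1 gives only the assay limit > 10000 nM.
Compound 2, `CNCC[C@@H]1CCOC(c2ccccc2)(c2ccccc2)O1`: in this assay compound 2 gives only the assay limit > 10000 nM.
Compound 3, `NCCC[C@@H]1CCO[C@H](c2ccccc2)O1`: in this assay compound 3 gives 167 nM.

Compounds 1 and 2 share one core, and compound 3 carries another; how the two cores differ is not broken down here. From compound 1 to compound 2 the change is methyl in place of hydrogen on an amine nitrogen. The step that the two limits leave unreadable from compound 1 to compound 2 cannot be read because both values sit at the limit of > 10000 nM in this assay, at which 2 of the 3 values shown sit.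

Compound 4, `CNCCC[C@@H]1CCO[C@H](c2ccccc2)O1`, has not yet been measured in this assay. It differs from compound 3 by methyl in place of hydrogen on an amine nitrogen, the same change as from compound 1 to compound 2, and the only one of its kind in this set. The earlier step is unreadable, so the expectation for compound 4 rests on compound 3, whose value 167 nM is the anchor, with the size of the change left open. For compound 4 the expected step is a 1.4-fold lower number from compound 3 to compound 4 (0.14 log units; within the scatter). Compound 4 is therefore estimated at 120 nM, with a range from 30 nM to 500 nM.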

Compound 4, inhibition constant: 327 nM
The estimate for compound 4 lay 2.7-fold (0.44 log units) below the measured number; measured number inside the range.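

In this assay, methyl in place of hydrogen on an amine nitrogen gives a 2.0-fold higher number from compound 3 to compound 4 (0.29 log units; within the scatter), so on this core the step cannot be told apart from repeated measurement. The same change on the other core cannot be read, because compound 1 and compound 2 both sit at an assay limit and not at a number: the limit of > 10000 nM in this assay, at which 2 of the 4 values shown sit. The series therefore offers one readable step and no second one to set against it, so it does not show whether the change carries from one core to the other, either as a similar result or as a different one.

Still open, on these data alone, is whether a larger group on the same amine nitrogen, such as ethyl or benzyl, or a second methyl giving a dimethylamino group, would also stay within the scatter on the core of compound 3. Also open is which feature of the two cores matters in this assay, since no pair shown differs in the core alone.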